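A few compounds are considered here, and "the series" means these few. Any claim that something is new, unique, unknown or untested is made for them only; others in the source may bear on it.

Measured in a functional assay on BaF3 cells (Mus musculus) for antiproliferative activity; on this read-out higher numbers stand for an effect only at larger amounts of compound and lower numbers for an effect already at smaller amounts:
compound 1 `CCN1CCN(Cc2ccc(NC(=O)c3ccc(C)c(C#Cc4ccc(NC(C)=O)nc4)c3)cc2C(F)(F)F)CC1`: 2050 nM
compound 2 `CCN1CCN(Cc2ccc(NC(=O)c3ccc(C)c(C#Cc4cnccn4)c3)cc2C(F)(F)F)CC1`: 2490 nM
compound 3 `CCN1CCN(Cc2ccc(NC(=O)c3ccc(C)c(C#Cc4cnc5[nH]c(C)cc5c4)c3)cc2C(F)(F)F)CC1`: 1000 nM

Compound 1 stands at the upper end of these numbers, level with compound 2 within the scatter: a 1.2-fold higher number from compound 1 to compound 2 (0.08 log units; within the scatter). Compound 3 gives the lowest number, and the step to it is a 2.1-fold lower number from compound 1 to compound 3 (0.31 log units; beyond the scatter).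

Compound 4 `CCN1CCN(Cc2ccc(NC(=O)c3ccc(C)c(C#Cc4cnc5[nH]cnc5c4)c3)cc2C(F)(F)F)CC1` remains unmeasured. Its change from compound 1 is a group of 9 heavy atoms (6 carbon, 3 nitrogen; one five-membered aromatic ring with 2 hetero atoms, one six-membered aromatic ring with 1 hetero atom) in place of a group of 10 heavy atoms (7 carbon, 2 nitrogen, 1 oxygen; one six-membered aromatic ring with 1 hetero atom), on a triple-bonded carbon. The 6-acetamidopyridin-3-yl group leaves, and the new group sits on the same triple-bonded carbon. Compound 3 is the closest measured precedent, as its group also holds a five-membered aromatic ring and a six-membered aromatic ring. Among the measured compounds shown here, its five-membered ring has 1 hetero atom, however, whereas the one in compound 4 has 2 hetero atoms, and no measured compound carries that ring.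

For the measured compounds named here, the steps that bear on this change are a 2.1-fold lower number from compound 1 to compound 3 (0.31 log units; beyond the scatter) and a 2.5-fold lower number from compound 2 to compound 3 (0.40 log units; beyond the scatter). Both are modest. The smaller pyrazin-2-yl group of compound 2 offers only the flat step a 1.2-fold higher number from compound 1 to compound 2 (0.08 log units; within the scatter). In this assay, a modest move to a lower number is therefore expected, close to the edge of the scatter. The estimated step is a 1.9-fold lower number from compound 1 to compound 4 (0.27 log units; within the scatter). The estimate for compound 4 is 1100 nM, with an expected range from 350 nM to 3000 nM.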

Compound 4, half-maximal effective concentration: 60 nM
Compound 4: the middle estimate sits 18-fold (1.26 log units) above what was measured; measured number below the stated range.
By their numbers in this assay, from the lowest: compound 4; then compound 3; then compounds 1 and 2 (each within the scatter of the next).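

On the triple-bonded carbon, this position supports far larger changes than the earlier modest steps showed: in this assay the entering group gives (a 34-fold lower number from compound 1 to compound 4 (1.53 log units; beyond the scatter)) and (a 42-fold lower number from compound 2 to compound 4 (1.62 log units; beyond the scatter)), although the groups exchanged between compound 1 and compound 4 have equal counts of hydrogen-bond donors and acceptors. A five-membered aromatic ring joined with a six-membered aromatic ring is not enough on its own, as compound 3 has both ring sizes and the change to the group with 2 hetero atoms in the five-membered ring and 9 heavy atoms still gives a large step (a 17-fold lower number from compound 3 to compound 4 (1.22 log units; beyond the scatter)). No measurement on hand explains why this group stands so far apart from the others.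

The step from compound 3 changes both the hetero atom count of the five-membered ring and the heavy atom count of the group, so the compounds shown do not separate the two. Also open, from the compounds shown here alone, is how far the result holds when the group of compound 4 carries a further substituent, such as a methyl group or an amine.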